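Amide substituent swaps on the shared core

This account rests on a few compounds, and the source may have more. Where it says the series, first, only, none or still open, it means among the compounds named here.

Compound 3 `C=CC1=C(C(=O)Nc2ccc(C)cc2)C(c2ccc(F)cc2)OC1` carries a 4-methylphenyl group on the amide-type nitrogen. In a functional assay on A549 cells (Homo sapiens) for cytotoxicity, read by MTT assay, with a stated time of 24 h (a lower number here means a stronger inhibitor, a higher number a weaker inhibitor), compound 3 gives only a limit, > 100000 nM. Compound 1 `C=CC1=C(C(=O)NCCC)C(c2ccc(F)cc2)OC1`, with propyl on that nitrogen, also gives only a limit in this assay, > 100000 nM. Compound 2 `C=CC1=C(C(=O)NCc2ccc(C)cc2)C(c2ccc(F)cc2)OC1`, with 4-methylbenzyl there, likewise gives only a limit in this assay, > 100000 nM. The steps a step that the two limits leave unreadable from compound 1 to compound 3, a step that the two limits leave unreadable from compound 2 to compound 3 and a step that the two limits leave unreadable from compound 1 to compound 2 are therefore of unreadable size; what the three values share is the limit of > 100000 nM in this assay, at which 3 of the 3 values shown sit.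

Compound 4 `C=CC1=C(C(=O)NCc2ccccc2)C(c2ccc(F)cc2)OC1` differs from compound 3 by benzyl in place of 4-methylphenyl on an amide-type nitrogen. Of the measured steps, the move from 4-methylbenzyl to 4-methylphenyl, a step that the two limits leave unreadable from compound 2 to compound 3, is the closest in kind. Compound 2 shows that a benzyl-type group on this nitrogen sits at the limit just as the aryl group does. The step that the limit leaves unreadable from compound 3 to compound 4 is thus expected to be none beyond the scatter. Compound 4 is estimated at 150000 nM in this assay, within 100000 nM to 300000 nM, most likely reported again as a limit.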

Compound 4, half-maximal inhibitory concentration: > 100000 nM
Compound 4: no number, only a limit (the forecaster's own chance of this, stated with the estimate: 85%); the middle value is on the limit's open side.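

In this assay compound 4 gives > 100000 nM as a limit and not a number, so the steps to compound 4 from compound 1, compound 2 and compound 3 cannot be read. The compounds shown leave open whether in this assay any amide substituent on the shared core gives a number rather than a limit.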